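One Ring Changed, One Number Still to Come

A few compounds are considered here, and "the series" means these few. Any claim that something is new, unique, unknown or untested is made for them only; others in the source may bear on it.

Of the compounds shown here, three have so far been tested in a functional assay on HeLa cells (Homo sapiens) for antiproliferative activity, read by sulforhodamine B assay, with a stated time of 72 h; a lower number here means a stronger inhibitor, a higher number a weaker inhibitor. Compound 1 `COc1ccc(C)cc1NC(=S)N/N=C/c1ccc2ccccc2n1` gives > 100000 nM, which is a limit of the assay rather than a number. Compound 2 `S=C(N/N=C/c1ccc2ccccc2n1)Nc1cccc(Br)c1` gives 70000 nM, the higher of the two numbers measured. Compound 3 `CN(C)C(=S)N/N=C/c1nc2ccccc2s1` gives 2100 nM, a much lower number, well beyond the scatter of repeated measurements. Compound 4 `COc1ccc(NC(=S)N/N=C/c2ccc3ccccc3n2)cc1` has not yet been tested; it differs from compound 2 in one place: 4-methoxyphenyl in place of 3-bromophenyl on an amide-type nitrogen. Among the compounds with values here, no measured pair differs in exactly this way, so the size of the step is open. The step from compound 2 to compound 4 is expected to be a 1.1-fold higher number from compound 2 to compound 4 (0.06 log units; within the scatter), no larger than the scatter. Compound 4 is therefore expected to give about 80000 nM, within a range from 30000 nM to 200000 nM.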

Compound 4, half-maximal inhibitory concentration: 72600 nM
Compound 4: middle estimate off by 1.1-fold (0.04 log units), on the high side, and the stated range covers the measured number.
By their numbers in this assay, from the lowest: compound 3; then compounds 2 and 4 (each within the scatter of the next). At a limit, above all of these: compound 1.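

On the amide-type nitrogen, 4-methoxyphenyl in place of 3-bromophenyl gives a 1.0-fold higher number from compound 2 to compound 4 (0.02 log units; within the scatter) in this assay. Within the data shown here, this is the first step measured at this position, and the entering group carries a hydrogen-bond acceptor that the leaving group lacks, yet the two numbers cannot be told apart. The scale of this measurement also has an upper end: the limit of > 100000 nM in this assay, at which 1 of the 4 values shown sits.

From the compounds shown here alone, what a group without an aromatic ring would do here, such as a longer chain ending in an amine or a carboxylic acid, stays open. So does whether this swap would behave the same way on another core.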